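Swapping Chloro for Methyl on an Aromatic Ring

The source may report more compounds than this note shows. Statements on the series, on what has been measured and on what is new or still open speak of the compounds shown alone.

Compound 1 `Cc1ccc(S(=O)(=O)N2CC(c3ccc(Br)cc3)NC2=O)cc1` and compound 2 `Cc1ccc(C2CN(S(=O)(=O)c3ccc(Cl)cc3)C(=O)N2)cc1` share a core, and both have been measured in a functional assay on SK-MEL-2 cells (Homo sapiens) for cytotoxicity (on this read-out higher numbers stand for weaker inhibition and lower numbers for stronger inhibition), so far. Compound 1 reads > 253000 nM as a limit of the assay and not a number. Among the compounds with values here, compound 2 gives 123000 nM as the only true number available, so it stands alone, with no other exact value to rank it against.

Compound 3 `Cc1ccc(C2CN(S(=O)(=O)c3ccc(C)cc3)C(=O)N2)cc1` keeps the core of compound 2 and alters one group: methyl in place of chloro on an aromatic carbon with methyl in place of chloro on an aromatic carbon, para to a large group. The same difference reads as 4-chlorophenyl to 4-methylphenyl. Within the data shown here, no measured pair differs in one place only, so the size of this swap in this assay has not been seen directly. The expectation is no change beyond the usual scatter, with a slight lean towards weaker inhibition, given that compound 1 sits at the limit of > 253000 nM as its reading. The expected step of a 1.2-fold higher number from compound 2 to compound 3 (0.09 log units; within the scatter) is therefore small. Compound 3 is estimated at about 150000 nM with a likely range from 70000 nM to 300000 nM on this read-out.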

Compound 3, half-maximal inhibitory concentration: > 302000 nM
Compound 3 gave a limit, no number (the forecaster's own chance of this, stated with the estimate: 30%); middle value at least 2.0-fold (0.30 log units) away from the limit.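

Within the data shown here, changing chloro to methyl on this aromatic carbon, para to a large group, gives the first direct reading of a one-place change: in this assay it produces an at least 2.4-fold higher number from compound 2 to compound 3 (0.39 log units; beyond the scatter). Chloro therefore goes with the stronger inhibition of this pair, although the swap leaves the heavy-atom count unchanged and neither group carries a hydrogen-bond donor or acceptor. The true size of the step remains unknown because compound 3 reads as a limit of the assay and not as a number: the limit of > 302000 nM in this assay, at which 1 of the 3 values shown sits.

Compound 1 and compound 3 both stand as limits, so the step between them cannot be read, and the shown compounds do not place bromo relative to methyl at this position. On these data alone, it also remains open whether the inhibition seen with chloro extends to other groups on this carbon, such as fluoro, methoxy or an amine, and whether any of them would give a reading that is a true number.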